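Swapping iodo for methoxy on a saturated ring carbon

A few compounds are considered here, and "the series" means these few. Any claim that something is new, unique, unknown or untested is made for them only; others in the source may bear on it.

Of the compounds shown here, two sharing one core have been measured so far in a functional assay on HT-29 cells (Homo sapiens) for cytotoxicity, read by MTT assay; on this read-out lower numbers stand for stronger inhibition and higher numbers for weaker inhibition. Compound 1 `C=C1C(=O)[C@]23C[C@@]1(Cl)CC[C@H]2[C@@]12C=CC(=O)[C@](C)(C(=O)O1)[C@H]2[C@@H]3C(=O)OC`, which carries chloro, gives 2900 nM. Compound 2 `C=C1C(=O)[C@]23C[C@@]1(I)CC[C@H]2[C@@]12C=CC(=O)[C@](C)(C(=O)O1)[C@H]2[C@@H]3C(=O)OC`, which carries iodo, gives 51900 nM, the higher of the two numbers and therefore the weaker result. Compound 3 `C=C1C(=O)[C@]23C[C@@]1(OC)CC[C@H]2[C@@]12C=CC(=O)[C@](C)(C(=O)O1)[C@H]2[C@@H]3C(=O)OC` has not been measured yet. It has methoxy in place of iodo on a saturated ring carbon.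

For the measured compounds named here, only one measured step bears on this change, and it concerns the same ring carbon. That step, an 18-fold higher number from compound 1 to compound 2 (1.25 log units; beyond the scatter), is large and lies beyond the scatter. Going by the values given here, it shows that the iodo compound sits well above the only other compound measured, so replacing iodo is expected to lower the number. Among the compounds with values here, no measured compound carries methoxy, however, so this single step gives only a rough guide to size. The estimated change is a 5.8-fold lower number from compound 2 to compound 3 (0.76 log units; beyond the scatter), a clear move to a lower number. For compound 3 the expected value is 9000 nM, with an estimated range from 2000 nM to 35000 nM.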

Compound 3, half-maximal inhibitory concentration: 80200 nM
Beside the measured number, compound 3's estimate is 8.9-fold (0.95 log units) below it, outside the stated range (above it).
By their numbers in this assay, from the lowest: compound 1; then compounds 2 and 3 (each within the scatter of the next).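

In this assay, methoxy in place of iodo on this saturated ring carbon gives a 1.5-fold higher number from compound 2 to compound 3 (0.19 log units; within the scatter) and so stays within the scatter: compounds 2 and 3 cannot be told apart on this read-out, although the two groups share no atoms and only methoxy counts a hydrogen-bond acceptor. The low number of compound 1 now stands apart from two different groups rather than one, since methoxy in place of chloro gives a 28-fold higher number from compound 1 to compound 3 (1.44 log units; beyond the scatter) and this large step runs the same way as the earlier step from chloro to iodo. Among these three compounds, then, chloro is the only group that gives a clearly lower number, and no measurement offered here accounts for that difference.

Still open, going by these compounds, is whether chloro alone gives this lower number or whether other groups on the same ring carbon, such as fluoro, hydroxyl, methyl or an amine, would match it. On these data alone, all three compounds differ at this one ring carbon, so the effect of changes elsewhere on the shared core also remains unknown.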